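The compounds below may be only part of what the source reports. "The series", "measured", "known", "first", "only" and "open" are said of these compounds alone.

Compound 1, `CC(C)=CCC(=O)Nc1ccn([C@H]2CC[C@H](O)[C@@H](C)O2)c(=O)n1`, carries a (3-methylbut-2-en-1-yl)carbonyl amide on the shared core. In a functional assay on HCT-116 cells (Homo sapiens) for cytotoxicity, read by sulforhodamine B assay, with a stated time of 24 h (a lower number here means a stronger inhibitor, a higher number a weaker inhibitor), compound 1 gives > 20000 nM, which is a limit of the assay and not a number. Compound 2, `CC(=O)C(C)Nc1ccc(C(=O)Nc2ccn([C@H]3CC[C@H](O)[C@@H](C)O3)c(=O)n2)cc1`, likewise returns a limit in this assay, > 20000 nM. Compound 3, `CC(C)CCC(=O)Nc1ccn([C@H]2CC[C@H](O[C@H]3O[C@H](C)[C@@H](N(C)C)[C@H](O)[C@H]3O)[C@@H](C)O2)c(=O)n1`, is the only one of the three with a measured number, and in this assay compound 3 gives 390 nM. Compound 1 therefore stands at the limit of > 20000 nM in this assay, at which 2 of the 3 values shown sit, and it cannot be ordered against compound 2.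

Compound 4, `CC(=O)Nc1ccn([C@H]2CC[C@H](O)[C@@H](C)O2)c(=O)n1`, differs from compound 1 in one place: hydrogen in place of 2-methylprop-1-en-1-yl on a saturated chain carbon bound to a carbonyl carbon. Cut one bond further out, the (3-methylbut-2-en-1-yl)carbonyl becomes acetyl. Among the measured compounds shown here, no step between measured compounds covers this change; what is known is that compound 1 sits at the limit. The expected step that the limit leaves unreadable from compound 1 to compound 4 is therefore no change beyond the scatter in this assay, and most probably a second limit rather than a number. Compound 4 is accordingly expected to give 40000 nM in this assay, within a range from 15000 nM to 150000 nM.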

Compound 4, half-maximal inhibitory concentration: > 20000 nM
Compound 4: a limit, no number; the forecaster's own chance of this, stated with the estimate: 85%; the middle value lies beyond the limit too.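

The step between compound 1 and compound 4 cannot be read, since both return a limit of the assay and not a number: the limit of > 20000 nM in this assay, at which 3 of the 4 values shown sit.

The compounds shown leave open whether hydrogen in place of 2-methylprop-1-en-1-yl on a saturated chain carbon bound to a carbonyl carbon changes anything in this assay.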